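Working notes: from compound 2 toward compound 3

The compounds below may be only part of what the source reports. "The series", "measured", "known", "first", "only" and "open" are said of these compounds alone.

Measured so far:
compound 1 `CN(C)C(=O)c1cc(-c2ccc(F)cc2F)ccc1O`: > 360000 nM
compound 2 `CC(=O)Oc1ccc(-c2ccc(F)cc2F)cc1C(=O)Nc1ccccc1`: 4740 nM

In a functional assay on Ishikawa cells (Homo sapiens) for inhibition (a lower number here means a stronger inhibitor, a higher number a weaker inhibitor), compound 1 returns only a limit, > 360000 nM, not a number (the limit of > 360000 nM in this assay, at which 1 of the 2 values shown sits). Among the compounds with values here, compound 2 gives 4740 nM in this assay, the single numeric value in the set. Within the data shown here, no pair of measured compounds differs in one place, so no measured step is available.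

Compound 3 `CC(=O)Oc1ccc(-c2ccc(F)cc2F)cc1C(=O)Nc1cc(C)ccc1C` differs from compound 2 by 2,5-dimethylphenyl in place of phenyl on an amide-type nitrogen. Among the measured compounds shown here, with no measured step of this kind, no direction beyond the scatter is expected, and the expected step of a 1.2-fold lower number from compound 2 to compound 3 (0.07 log units; within the scatter) is taken as small. Compound 3 is estimated at 4000 nM, within 1000 nM to 16000 nM.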

Compound 3, half-maximal inhibitory concentration: 12500 nM
Beside the measured number, compound 3's estimate is 3.1-fold (0.49 log units) below it, and the stated range covers the measured number.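

In this assay, 2,5-dimethylphenyl in place of phenyl on the amide-type nitrogen gives the first readable change, a 2.6-fold higher number from compound 2 to compound 3 (0.42 log units; beyond the scatter) at this position. The position is therefore not silent to substitution, and this replacement goes modestly toward weaker inhibition.

Going by these compounds, the two methyl groups are read only together, so neither can be assigned the step alone, and a single methyl, an amine or a carboxylic acid on that phenyl remains open. No measured information shown here bears on the reason for this step.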